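This account rests on a few compounds, and the source may have more. Where it says the series, first, only, none or still open, it means among the compounds named here.

Compound 1, `COc1ccc2c(c1)OC(c1cccc([N+](=O)[O-])c1)C(c1ccccc1)C2=O`, reaches only a limit of > 2500000 nM in an ADME assay on PBMC cells (Homo sapiens) for cytotoxicity, read by MTT assay, with a stated time of 5 days; on this read-out lower numbers stand for higher toxicity in this test and higher numbers for lower toxicity in this test. Compound 2, `COc1ccc2c(c1)OC(c1ccc([N+](=O)[O-])cc1)C(c1ccccc1)C2=O`, gives 595000 nM in this assay.

Compound 2 therefore holds the only numerical result in this assay; the other value is a limit. Compound 3, `COc1ccc2c(c1)OC(c1ccc(Cl)cc1)C(c1ccccc1)C2=O`, differs from compound 2 by chloro in place of nitro on an aromatic carbon. For the measured compounds named here, the single measured step, an at least 4.2-fold lower number from compound 1 to compound 2 (0.62 log units; beyond the scatter), changed where the nitro sits rather than what it is, so it bears only loosely on this exchange. The expectation is for a change of no more than a 1.0-fold higher number from compound 2 to compound 3 (0.00 log units; within the scatter). Compound 3 is accordingly estimated at 600000 nM, with a range from 150000 nM to 2500000 nM.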

Compound 3, half-maximal cytotoxic concentration: > 2500000 nM
Compound 3: a limit, no number; the forecaster's own chance of this, stated with the estimate: 35%; at least 4.1-fold (0.61 log units) between middle value and limit.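

In this assay, chloro in place of nitro on the aromatic carbon para to a large group gives an at least 4.2-fold higher number from compound 2 to compound 3 (0.62 log units; beyond the scatter). Compound 3 keeps the group in that same place, so the lower number of compound 2 goes with the nitro itself and not with the place alone. The step between compound 1 and compound 3 cannot be read, and only compound 2 has a true number: the limit of > 2500000 nM in this assay, at which 2 of the 3 values shown sit.

Going by these compounds, how far compound 1 and compound 3 lie past their limit remains unknown. Also open, on these data alone, is whether an amine or a carboxylic acid in this place would give a number like that of the nitro or a limit like that of the chloro.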